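Series notes: hepatocyte clearance of a shared core

This account rests on a few compounds, and the source may have more. Where it says the series, first, only, none or still open, it means among the compounds named here.

Measured compounds:
compound 1 `COc1cc(F)ccc1-c1ccnc2[nH]c(C3CCN(CC(=O)N(C)C)CC3)cc12`: 38 uL/min
compound 2 `COc1cc(F)ccc1-c1ccnc2[nH]c(C3CCN(C(C)=O)CC3)cc12`: 50 uL/min

In an ADME assay on cells (Hepatocyte, Rattus norvegicus) for metabolic stability (a lower number here means slower removal, a higher number faster removal of the compound), compound 1 gives the lowest of the two numbers; the nearest is compound 2, with a 1.3-fold higher number from compound 1 to compound 2 (0.12 log units; within the scatter). Compound 3 `CCn1cc(-c2ccnc3[nH]c(C4CCN(CC(=O)N(C)C)CC4)cc23)ccc1=O` differs from compound 1 as follows: a group of 9 heavy atoms (7 carbon, 1 nitrogen, 1 oxygen; one six-membered aromatic ring with 1 hetero atom) in place of a group of 9 heavy atoms (7 carbon, 1 oxygen, 1 fluorine; one six-membered aromatic ring of carbon only), on an aromatic carbon. Among the measured compounds shown here, the one measured step changes the amine substituent, not the aromatic group, so no measured step bears on this change and no direction can be drawn from the data. For compound 3 the expected step is a 1.1-fold lower number from compound 1 to compound 3 (0.04 log units; within the scatter), taken as no change beyond the scatter. The estimate for compound 3 in this assay is 35 uL/min, range 15 uL/min to 80 uL/min.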

Compound 3, intrinsic clearance in a liver preparation (reported as CLH), per the amount of preparation that the assay uses: < 1 uL/min
Compound 3: a limit, no number (the forecaster's own chance of this, stated with the estimate: 5%); at least 35-fold (1.54 log units) between middle value and limit.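

In this assay the aromatic carbon opposite the ring nitrogen is where the read-out moves: the group of compound 3 in place of 4-fluoro-2-methoxyphenyl gives (an at least 38-fold lower number from compound 1 to compound 3 (1.57 log units; beyond the scatter)) with the amine substituent unchanged. Among the compounds shown here, the earlier step, on the ring amine, stayed within the scatter, so this is the first change beyond it. The figure for compound 3 is a limit, not a number: the limit of < 1 uL/min in this assay, at which 1 of the 3 values shown sits.

Going by these compounds, the ring nitrogen, carbonyl and ethyl enter together, and which of them carries the step stays open. Also open, on these data alone, is what a methyl in place of that ethyl, or a plain pyridine ring, would give at this position.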